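The compounds below may be only part of what the source reports. "The series", "measured", "known", "first", "only" and "open" are said of these compounds alone.

Measured so far:
- compound 1, `CCn1c(C(=O)NCCN)ccc1C(CC)(CC)c1ccc(OCC(=O)C(C)(C)C)c(C)c1`: 120 nM
- compound 2, `C=CCN(C)C(=O)c1ccc(C(CC)(CC)c2ccc(OCC(=O)C(C)(C)C)c(C)c2)n1CC`: 21600 nM
- compound 3, `CCn1c(C(=O)N(C)c2ccccc2)ccc1C(CC)(CC)c1ccc(OCC(=O)C(C)(C)C)c(C)c1`: 18500 nM

In an assay on HL-60 cells for agonist activity at vitamin D3 receptor (Homo sapiens), read by microscopy, with a stated time of 96 h (a higher number here means that more compound is needed for the effect, a lower number that less compound is needed), compound 3 gives the second highest of the three numbers. Its nearest neighbour is compound 2, a gap that is a 1.2-fold lower number from compound 2 to compound 3 (0.07 log units; within the scatter), so the two cannot be told apart. Compound 1 lies far away: a 150-fold higher number from compound 1 to compound 3 (2.19 log units; beyond the scatter), and likewise a 180-fold higher number from compound 1 to compound 2 (2.26 log units; beyond the scatter). Both large steps share one feature: the (2-aminoethyl)amino group of compound 1 is replaced by a group that carries no hydrogen on the amide-type nitrogen.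

Compound 4, `CCn1c(C(=O)Nc2ccc(OC(F)(F)F)cc2)ccc1C(CC)(CC)c1ccc(OCC(=O)C(C)(C)C)c(C)c1`, differs from compound 3 in that ((4-(trifluoromethoxy)phenyl)amino in place of methyl(phenyl)amino on a carbonyl carbon). This change does two things at once: the methyl on the amide-type nitrogen is removed, and a trifluoromethoxy group is added to the phenyl. Neither part is tested directly by the measured steps. The swap of allyl for phenyl on that nitrogen, a 1.2-fold lower number from compound 2 to compound 3 (0.07 log units; within the scatter), shows that the group on the nitrogen itself can be changed without effect, while the steps from compound 1 show that the surroundings of the carbonyl matter greatly. A moderate step towards a lower number, a 3.1-fold lower number from compound 3 to compound 4 (0.49 log units; beyond the scatter), is therefore expected for compound 4, with wide uncertainty, giving an estimated 6000 nM within 800 nM to 40000 nM.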

Compound 4, half-maximal effective concentration: > 50000 nM
Compound 4: a limit, no number; the forecaster's own chance of this, stated with the estimate: 10%; middle value at least 8.3-fold (0.92 log units) away from the limit.
By their numbers in this assay, from the lowest: compound 1; then compounds 3 and 2 (each within the scatter of the next). At a limit, above all of these: compound 4.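

The value of compound 4 is a limit, not a number: the limit of > 50000 nM in this assay, at which 1 of the 4 values shown sits. An amide hydrogen on the nitrogen is therefore not enough to give a low number at this position, as the change shows an at least 410-fold higher number from compound 1 to compound 4 (2.61 log units; beyond the scatter). Compound 4 also sits beyond the two compounds that lack that hydrogen, with an at least 2.7-fold higher number from compound 3 to compound 4 (0.43 log units; beyond the scatter) and an at least 2.3-fold higher number from compound 2 to compound 4 (0.36 log units; beyond the scatter), so among the compounds shown, only the 2-aminoethyl group of compound 1 gives a low number on this carbonyl carbon.

Removing the methyl and adding the trifluoromethoxy group arrive together in compound 4, and the compounds shown do not separate their contributions. Also open, from the compounds shown here alone, is what a plain phenylamino group, a longer chain ending in an amine, or a carboxylic acid in place of that amine would give here.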